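This account rests on a few compounds, and the source may have more. Where it says the series, first, only, none or still open, it means among the compounds named here.

Compound 1 `CCNC(=O)Nc1cccc2c1CN(C)CC2c1ccccc1`: 80 mg/kg
Compound 2 `CCOC(=O)Nc1cccc2c1CN(C)CC2c1ccccc1`: 3.2 mg/kg
Compound 3 `CCCCNCC(=O)Nc1cccc2c1CN(C)CC2c1ccccc1`: 32 mg/kg

All three values come from a functional assay on the whole organism for inhibition, with Mus musculus as the target; on this read-out lower numbers stand for an effect already at smaller amounts and higher numbers for an effect only at larger amounts of compound. Compound 3, at 32 mg/kg, lies in the middle of the three numbers, as a 2.5-fold lower number from compound 1 to compound 3 (0.40 log units; beyond the scatter) and a 10-fold higher number from compound 2 to compound 3 (1.00 log units; beyond the scatter) show.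

Compound 4 `CN1Cc2c(NC(=O)CN3CCCCC3)cccc2C(c2ccccc2)C1` keeps the shared core of compound 3 and differs in one place: piperidin-1-yl in place of butylamino on a saturated chain carbon bound to a carbonyl carbon. In words, piperidin-1-yl stands in place of butylamino on a saturated chain carbon bound to a carbonyl carbon.

Going by the values given here, no measured pair shows this exchange. The available steps, including the largest, a 25-fold lower number from compound 1 to compound 2 (1.40 log units; beyond the scatter), all replace a group on a carbonyl carbon. They show that this part of the molecule can matter, but they give neither the size nor the direction of the new step. No step beyond the scatter is therefore expected in this assay, though with wide uncertainty.

The expected step is a 1.1-fold lower number from compound 3 to compound 4 (0.03 log units; within the scatter). The estimate for compound 4 is 30 mg/kg, with an expected range of 10 mg/kg to 90 mg/kg.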

Compound 4, dose for half-maximal effect: about 65 mg/kg
The estimate for compound 4 lay 2.2-fold (0.34 log units) below the measured number, within the range that was stated.
By their numbers in this assay, from the lowest: compound 2; then compound 3; then compounds 4 and 1 (each within the scatter of the next).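

Going by these compounds alone, replacing butylamino with piperidin-1-yl on a saturated chain carbon bound to a carbonyl carbon gives a 2.0-fold higher number from compound 3 to compound 4 (0.31 log units; beyond the scatter) in this assay, so the group at this place also matters, which the earlier steps, all made on the carbonyl carbon, did not show. The measured steps of a 1.2-fold lower number from compound 1 to compound 4 (0.09 log units; within the scatter) and a 20-fold higher number from compound 2 to compound 4 (1.31 log units; beyond the scatter) place compound 4 within the scatter of compound 1 and well apart from compound 2. No measurement available here accounts for the new step.

This step joins two differences, the closed ring and the loss of the hydrogen-bond donor, and the compounds shown do not separate them. A diethylamino group on the same carbon, open-chain and without that donor, would be the kind of comparison needed to tell them apart.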